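Fluoro for Bromo in a Series Sitting at the Limit

This account rests on a few compounds, and the source may have more. Where it says the series, first, only, none or still open, it means among the compounds named here.

Three compounds built on a shared core were tested in a functional assay on A549 cells (Homo sapiens) for cytotoxicity, read by MTT assay, with a stated time of 4 days; on this read-out lower numbers stand for stronger inhibition and higher numbers for weaker inhibition. Compound 1 `Cc1c(O)ccc2c1[C@H](Cn1cc(-c3ccccn3)nn1)[C@@]13CC(=O)[C@@](C)(CC[C@@H]21)C3` reached only the limit of the assay, giving > 20000 nM in this assay. Compound 3 `C=C1C[C@]23C[C@@]1(O)CC[C@H]2c1cc(Br)c(O)c(C)c1[C@@H]3Cn1cc(-c2ccccc2)nn1` likewise returned a limit, > 20000 nM, in this assay. Compound 2 `C=C1C[C@]23C[C@@]1(O)CC[C@@H]2c1cccc(C)c1[C@@H]3Cn1cc(-c2ccc(Br)cc2)nn1` stands with them: in this assay compound 2 gives > 20000 nM, again a limit rather than a number. For the measured compounds named here, none of the three yields a measured figure, so no step between measured values can be read; what they share is the limit of > 20000 nM in this assay, at which 3 of the 3 values shown sit.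

Compound 4 `C=C1C[C@]23C[C@@]1(O)CC[C@@H]2c1cccc(C)c1[C@@H]3Cn1cc(-c2ccc(F)cc2)nn1` differs from compound 2 by fluoro in place of bromo on an aromatic carbon. With every measured neighbour sitting at the limit, the data offer no direction for this change. The step expected here is a step that the limit leaves unreadable from compound 2 to compound 4, no larger than the usual scatter, most likely ending again at the limit. The estimate for compound 4 in this assay is 25000 nM, within a range from 10000 nM to 60000 nM.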

Compound 4, half-maximal inhibitory concentration: > 20000 nM
Compound 4: only a limit was reported (the forecaster's own chance of this, stated with the estimate: 85%); the middle value does not contradict the limit.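

Compound 2 and compound 4 both return only a limit, so no new step can be read between them: the limit of > 20000 nM in this assay, at which 4 of the 4 values shown sit. The compounds shown leave open both the size and direction of the change from bromo to fluoro, and which structure on the shared core would give a measured figure.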